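Swapping the amide aryl group: from halogenated phenyl to cyanophenyl

The source may hold more compounds than are shown below. What is called first, only, known or untested is meant among the compounds shown, and "the series" means these compounds.

Measured so far:
- compound 1, `COc1ccc(C(=O)Nc2cccc(-c3oc4cc(-c5ccc(F)cc5)ccc4c(=O)c3O)c2)cc1`: 8700 nM
- compound 2, `Cc1ccccc1C(=O)Nc1cccc(-c2oc3cc(-c4ccc(F)cc4)ccc3c(=O)c2O)c1`: 17600 nM
- compound 3, `O=C(Nc1cccc(-c2oc3cc(-c4ccc(F)cc4)ccc3c(=O)c2O)c1)c1ccc(Br)cc1F`: 46100 nM

All three compounds share one core and differ only in the aryl group attached to the carbonyl carbon of the amide. In a functional assay on A549 cells (Homo sapiens) for antiproliferative activity, read by CCK-8 assay, with a stated time of 72 h (a higher number here means a weaker inhibitor, a lower number a stronger inhibitor), compound 1 gives 8700 nM, compound 2 gives 17600 nM, and compound 3 gives 46100 nM. Compound 3 therefore stands highest of the three, that is, it is the weakest inhibitor among them: the change recorded as a 5.3-fold higher number from compound 1 to compound 3 (0.72 log units; beyond the scatter) and the change recorded as a 2.6-fold higher number from compound 2 to compound 3 (0.42 log units; beyond the scatter) are both modest but beyond the scatter.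

Compound 4, `N#Cc1ccc(C(=O)Nc2cccc(-c3oc4cc(-c5ccc(F)cc5)ccc4c(=O)c3O)c2)cc1`, is not yet measured. It differs from compound 3 by 4-cyanophenyl in place of 4-bromo-2-fluorophenyl on a carbonyl carbon. Within the data shown here, the steps that bear on this change are the two that lead into compound 3: walking them backwards, a return to a phenyl carrying a single group on the carbonyl side gave a lower number in both cases, by a 5.3-fold higher number from compound 1 to compound 3 (0.72 log units; beyond the scatter) and a 2.6-fold higher number from compound 2 to compound 3 (0.42 log units; beyond the scatter) when read in the forward direction. Among the measured compounds shown here, no measured step involves a cyanophenyl group, so the size of the effect of that particular group is unknown; the expectation rests only on compound 4 leaving the 4-bromo-2-fluorophenyl group that belongs to the highest number. On that basis compound 4 is expected to show a modestly lower number than compound 3, a step of about a 3.1-fold lower number from compound 3 to compound 4 (0.49 log units; beyond the scatter) in this assay. The estimated value for compound 4 is 15000 nM, with a range from 5000 nM to 50000 nM.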

Compound 4, half-maximal inhibitory concentration: 2360 nM
For compound 4 the middle estimate is 6.4-fold (0.80 log units) above the measured one, outside the stated range (below it).
By their numbers in this assay, from the lowest: compound 4; then compound 1; then compound 2; then compound 3.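

In this assay, the aryl group on the amide carbonyl carbon proves able to strengthen activity well beyond what the first three compounds suggested: 4-cyanophenyl in place of 4-bromo-2-fluorophenyl gives a 20-fold lower number from compound 3 to compound 4 (1.29 log units; beyond the scatter), the only large step among those shown, and compound 4 becomes the strongest of the four. The new group also improves on the two other aryl groups, with a 7.5-fold lower number from compound 2 to compound 4 (0.87 log units; beyond the scatter) against the 2-methylphenyl group and a 3.7-fold lower number from compound 1 to compound 4 (0.57 log units; beyond the scatter) when cyano takes the place of methoxy on an aromatic carbon, so the 4-methoxyphenyl group of compound 1 did not mark the best this position can give. No measurement shown accounts for this order.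

As far as these compounds go, whether the gain belongs to the nitrile itself remains open, and a plain phenyl, a 4-aminophenyl or a 4-carboxyphenyl group in the same place would help to settle that. Also open, from the compounds shown here alone, is whether 4-cyanophenyl would keep its lead on a core other than the shared one.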